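This account rests on a few compounds, and the source may have more. Where it says the series, first, only, none or still open, it means among the compounds named here.

Among the measured compounds shown here, in an assay on isolated protein for inhibition of Neprilysin (Rattus norvegicus) (on this read-out lower numbers stand for stronger inhibition and higher numbers for weaker inhibition), compound 2 `O=C(O)CN1C(=O)[C@@H](NC(=O)[C@@H](S)Cc2ccccc2)CCC[C@@H]1CCO` gives 31 nM, the lowest number of the two measured so far, while compound 1 `CC(C)[C@@H](C(=O)O)N1CCCC[C@H](NC(=O)[C@@H](S)Cc2ccccc2)C1=O` gives 1000 nM, a gap that lies beyond the usual scatter. Compound 3 `O=C(O)CN1C(=O)[C@@H](NC(=O)[C@@H](S)Cc2ccccc2)CCC[C@@H]1CC1CC1` differs from compound 2 in one place: cyclopropyl in place of hydroxymethyl on a saturated chain carbon bound to a saturated ring carbon. For the measured compounds named here, no measured pair isolates this change, so the account can only weigh it. A loss of the hydroxyl is expected to cost some inhibition in this assay, and the step from compound 2 to compound 3 is estimated as a 2.6-fold higher number from compound 2 to compound 3 (0.41 log units; beyond the scatter). Compound 3 is therefore expected at about 80 nM, likely between 20 nM and 300 nM.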

Compound 3, half-maximal inhibitory concentration: 140 nM
Compound 3: middle estimate off by 1.8-fold (0.24 log units), on the low side, and the stated range covers the measured number.
By their numbers in this assay, from the lowest: compound 2; then compound 3; then compound 1.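

In this assay, cyclopropyl in place of hydroxymethyl on a saturated chain carbon bound to a saturated ring carbon gives a 4.5-fold higher number from compound 2 to compound 3 (0.65 log units; beyond the scatter), so this position responds to the group placed there. Read one bond further out, the change is 2-hydroxyethyl to cyclopropylmethyl, and inhibition persists, with compound 3 at 140 nM, even though the entering group has no hydrogen-bond donor or acceptor. Nothing available explains the step. The compounds shown leave open whether the loss of the hydroxyl or the arrival of the ring accounts for it. A 2-methoxyethyl, 2-aminoethyl or plain propyl group at this place would help separate the two.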